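The source may hold more compounds than are shown below. What is called first, only, known or untested is meant among the compounds shown, and "the series" means these compounds.

Compound 1, `O=C(Nc1ccc(S(=O)(=O)N2CCNCC2)cc1)c1ccc([N+](=O)[O-])o1`: 26400 nM
Compound 2, `O=C(Nc1ccc(S(=O)(=O)N2CCC(O)CC2)cc1)c1ccc([N+](=O)[O-])o1`: 2000 nM

Within the data shown here, in an assay on CHO-K1 cells for activation of DNA damage-inducible transcript 3 protein (Homo sapiens), read by a luciferase reporter (a higher number here means that more compound is needed for the effect, a lower number that less compound is needed), compound 2 holds the lower of the two numbers measured so far; its only neighbour is compound 1, and the single measured step, a 13-fold lower number from compound 1 to compound 2 (1.12 log units; beyond the scatter), separates them. Compound 3, `O=C(Nc1ccc(S(=O)(=O)N2CCC(F)CC2)cc1)c1ccc([N+](=O)[O-])o1`, follows from compound 2 by fluoro in place of hydroxy on a saturated ring carbon. Among the measured compounds shown here, no measured step exchanges a hydroxy for a fluoro, so nothing bears on this change directly; the one step that exists, a 13-fold lower number from compound 1 to compound 2 (1.12 log units; beyond the scatter), replaced piperazin-1-yl with 4-hydroxypiperidin-1-yl, a change at a different place, and it shows only that the numbers in this assay can move a long way with a small change on this ring. For the measured compounds named here, with no direct precedent, and with the hydroxy group, which counts as one hydrogen-bond donor and one hydrogen-bond acceptor, being removed, a moderate rise in the number is expected, but with a wide range. Compound 3 is estimated to give 4500 nM, between 1200 nM and 18000 nM. The step this estimate implies is expected to be a 2.3-fold higher number from compound 2 to compound 3 (0.35 log units; beyond the scatter).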

Compound 3, concentration for half-maximal activity: 600 nM
Beside the measured number, compound 3's estimate is 7.5-fold (0.88 log units) above it, outside the stated range (below it).
By their numbers in this assay, from the lowest: compound 3; then compound 2; then compound 1.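

In this assay, the position three ring bonds from the ring nitrogen does not depend on a hydroxy group: the exchange for fluoro, which counts as neither a hydrogen-bond donor nor a hydrogen-bond acceptor, gives a 3.3-fold lower number from compound 2 to compound 3 (0.52 log units; beyond the scatter) and so runs against any need for the hydroxy group's donor or acceptor at this carbon. The earlier step had shown only that 4-hydroxypiperidin-1-yl was better than piperazin-1-yl on the sulfonyl sulfur, whereas 4-fluoropiperidin-1-yl widens that gain to a 44-fold lower number from compound 1 to compound 3 (1.64 log units; beyond the scatter) and shows that this ring position still has room to move the number after the hydroxy compound. No measurement offered here explains why fluoro gives the lower number.

The compounds shown leave open whether fluoro itself matters or whether removing the hydroxy group is enough, a question that the plain piperidin-1-yl ring, with only hydrogen on that carbon, would address. They also leave open how a methoxy group, an amine or a second fluorine on the same carbon would compare with fluoro.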